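Methoxy on the Distal Phenyl of Compound 1

This account rests on a few compounds, and the source may have more. Where it says the series, first, only, none or still open, it means among the compounds named here.

Measured so far:
Compound 1 `COc1cc(/C=C/C(=O)c2cccc(-n3cc(-c4ccccc4)[nH]c3=O)c2)ccc1O`: 1480 nM
Compound 2 `O=C(/C=C/c1cccc(O)c1)c1cccc(-n2cc(-c3ccccc3)[nH]c2=O)c1`: 6930 nM

In a functional assay on HOP-62 cells (Homo sapiens) for inhibition (a lower number here means a stronger inhibitor of growth, a higher number a weaker inhibitor of growth), compound 1 gives 1480 nM, the lowest of the two numbers. Its nearest neighbour is compound 2, which gives 6930 nM in this assay. For the measured compounds named here, the one measured step, a 4.7-fold higher number from compound 1 to compound 2 (0.67 log units; beyond the scatter), concerns the aryl end of the chain: 3-hydroxyphenyl in place of 4-hydroxy-3-methoxyphenyl on a double-bonded chain carbon bound to a double-bonded chain carbon.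

Compound 3 `COc1ccc(-c2cn(-c3cccc(C(=O)/C=C/c4ccc(O)c(OC)c4)c3)c(=O)[nH]2)cc1` keeps that chain end of compound 1 unchanged and differs from it only at the other phenyl: methoxy in place of hydrogen on an aromatic carbon, placed para to a large group, so that the phenyl becomes 4-methoxyphenyl. Going by the values given here, no measured step touches this phenyl, so the step from compound 1 to compound 2 does not bear on it, and nothing in the data points in either direction. The expected step, a 1.0-fold higher number from compound 1 to compound 3 (0.01 log units; within the scatter), is therefore one within the scatter. Compound 3 is estimated at 1500 nM in this assay, with a range from 500 nM to 4500 nM.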

Compound 3, concentration for 50% growth inhibition: 5150 nM
Compound 3: middle estimate off by 3.4-fold (0.54 log units), on the low side, and the stated range ends below it.
By their numbers in this assay, from the lowest: compound 1; then compounds 3 and 2 (each within the scatter of the next).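

The other phenyl is not a silent position in this assay: methoxy in place of hydrogen on an aromatic carbon, para to a large group, gives a step beyond the scatter (a 3.5-fold higher number from compound 1 to compound 3 (0.54 log units; beyond the scatter)), and the number moves towards weaker growth inhibition. For the compounds shown here, until this result, only the aryl end of the chain had been seen to change the number, so compound 3 shows that the phenyl at the other end of compound 1 also responds to a change. Nothing available gives a reason for this step, so only its size and direction can be stated.

The compounds shown carry only hydrogen or methoxy on this phenyl, so it remains open whether a hydroxy group, a fluorine atom or a dimethylamino group in the same place would leave the number near that of compound 1 or raise it as methoxy does. On these data alone, it also remains open whether 4-methoxyphenyl would give a step of similar size if the 3-hydroxyphenyl chain end of compound 2 were kept in place of that of compound 1.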